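Methyl on the five-membered ring of compound 1

A few compounds are considered here, and "the series" means these few. Any claim that something is new, unique, unknown or untested is made for them only; others in the source may bear on it.

Compound 1 `CCCc1c(OCCCCOc2ccc(-c3nn[nH]n3)cc2)ccc2c1ccn2CC(C)(C)C` gives 559 nM in a functional assay for binding affinity to metabotropic glutamate receptor 2 (Homo sapiens), read by GTPgammaS binding, with a stated time of 1 h, at 30 degrees C (on this read-out higher numbers stand for an effect only at larger amounts of compound and lower numbers for an effect already at smaller amounts), the lowest of the three numbers shown, though within the scatter of both others. Compound 2 `CCCCCn1ccc2c(CCC)c(OCCCCOc3ccc(-c4nn[nH]n4)cc3)ccc21` gives 598 nM and compound 3 `Cc1c(OCCCCOc2ccc(-c3nn[nH]n3)cc2)ccc2c1ccn2CC(C)(C)C` gives 1070 nM. The steps of a 1.1-fold higher number from compound 1 to compound 2 (0.03 log units; within the scatter) and a 1.9-fold higher number from compound 1 to compound 3 (0.28 log units; within the scatter) both stay within the scatter. Compound 4 `CCCc1c(OCCCCOc2ccc(-c3nn[nH]n3)cc2)ccc2c1cc(C)n2CC(C)(C)C` differs from compound 1 by methyl in place of hydrogen on an aromatic carbon, a site not varied among the measured compounds. The two measured steps touch other parts of the shared core and bear only indirectly: both show that single small changes around compound 1 leave the number where it was. No step beyond the scatter is therefore expected in this assay, in either direction. Compound 4 is expected at 600 nM, range 250 nM to 1500 nM. The expected step is a 1.1-fold higher number from compound 1 to compound 4 (0.03 log units; within the scatter).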

Compound 4, half-maximal effective concentration: 559 nM
Compound 4: middle estimate off by 1.1-fold (0.03 log units), on the high side; measured number inside the range.
By their numbers in this assay, from the lowest: compounds 1, 4, 2 and 3 (each within the scatter of the next).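

In this assay, among these compounds, methyl in place of hydrogen on an aromatic carbon next to the ring nitrogen gives no change at the digits printed from compound 1 to compound 4 (within the scatter), the first reading at a site the earlier compounds left unvaried. This site therefore takes one added carbon with no step beyond the scatter, even next to the ring atom that bears the neopentyl group. No measurement on hand bears on why the number holds.

Still open, as far as these compounds go, is whether a longer chain, an amine or a carboxylic acid on this carbon would leave the number equally undisturbed.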